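Oxazole ketone series: ester-for-amide swap on the pyridine

A few compounds are considered here, and "the series" means these few. Any claim that something is new, unique, unknown or untested is made for them only; others in the source may bear on it.

Compound 2 `NC(=O)c1ccc(-c2cnc(C(=O)CCc3ccc(-c4ccccc4)cc3)o2)nc1` gives 1.3 nM in an assay for inhibition of Fatty-acid amide hydrolase 1 (Rattus norvegicus) (on this read-out higher numbers stand for weaker inhibition and lower numbers for stronger inhibition), and stands lowest of the two numbers recorded; compound 1 `COC(=O)c1cccc(-c2cnc(C(=O)CCc3ccc(-c4ccc(CN5CCCC5)cc4)cc3)o2)n1` gives 18 nM in this assay, a gap beyond the scatter. Compound 3 `COC(=O)c1cccc(-c2cnc(C(=O)CCc3ccc(-c4ccccc4)cc3)o2)n1` is unmeasured; it differs from compound 2 by 6-(methoxycarbonyl)pyridin-2-yl in place of 5-carbamoylpyridin-2-yl on an aromatic carbon. Among the compounds with values here, no directly comparable step exists, and compound 1 differs in a second place as well, so its number is only a loose guide. The step from compound 2 to compound 3 is expected to run toward weaker inhibition, about a 4.6-fold higher number from compound 2 to compound 3 (0.66 log units; beyond the scatter). For compound 3 the estimate is 6 nM, expected between 1.5 nM and 25 nM.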

Compound 3, inhibition constant: 1.2 nM
Beside the measured number, compound 3's estimate is 5.0-fold (0.70 log units) above it; the whole stated range lies above it.
By their numbers in this assay, from the lowest: compounds 3 and 2 (each within the scatter of the next); then compound 1.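

At the aromatic carbon next to the ring oxygen, 6-(methoxycarbonyl)pyridin-2-yl and 5-carbamoylpyridin-2-yl are not told apart in this assay, with a 1.1-fold lower number from compound 2 to compound 3 (0.03 log units; within the scatter), even though the carbamoyl group's hydrogen-bond donor is gone. The large step in this series instead goes with hydrogen in place of (pyrrolidin-1-yl)methyl, at a 15-fold lower number from compound 1 to compound 3 (1.18 log units; beyond the scatter). Nothing available explains either step. Open: the pyridine swap changes both the group and its ring placement, so the two remain unseparated. Going by these compounds, a carboxylic acid or an amine in place of the ester also remains open.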